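A few compounds are considered here, and "the series" means these few. Any claim that something is new, unique, unknown or untested is made for them only; others in the source may bear on it.

In an ADME assay on microsomes from liver (Homo sapiens) for metabolic stability (on this read-out lower numbers stand for a shorter-lived compound and higher numbers for a longer-lived compound), compound 3 `COc1ccccc1-c1cc(C2=Nc3c(C(C)(C)C)nn(CCCO)c3C(=O)NC2)ccc1OC` gives 1.37 h and stands second highest of the three numbers, nearest to compound 1 `COc1ccc(OC)c(-c2cc(C3=Nc4c(C(C)(C)C)nn(CCCO)c4C(=O)NC3)ccc2OC)c1`, which gives 1.02 h, and furthest from compound 2 `COc1ccc(C2=Nc3c(C(C)(C)C)nn(CCCO)c3C(=O)NC2)cc1-c1ccc(F)cc1F`, which gives 2 h; both gaps lie within the scatter. Compound 4 `COc1ccc(C2=Nc3c(C(C)(C)C)nn(CCCO)c3C(=O)NC2)cc1-c1ccccc1SC` differs from compound 3 by methylsulfanyl in place of methoxy on an aromatic carbon. Going by the values given here, two measured steps bear on this change: a 1.3-fold higher number from compound 1 to compound 3 (0.13 log units; within the scatter), and a 1.5-fold lower number from compound 2 to compound 3 (0.16 log units; within the scatter). Each exchanges the group on that aromatic carbon and each stays within the scatter, so no step beyond the scatter is expected in this assay. The expected step is a 1.1-fold lower number from compound 3 to compound 4 (0.02 log units; within the scatter). Compound 4 is therefore estimated at 1.3 h, with a range from 0.6 h to 2.8 h.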

Compound 4, half-life: 0.85 h
The estimate for compound 4 lay 1.5-fold (0.18 log units) above the measured number; the measured number falls inside the stated range.
By their numbers in this assay, from the lowest: compounds 4, 1, 3 and 2 (each within the scatter of the next, the first and the last beyond it).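

In this assay, methylsulfanyl in place of methoxy, ortho to a large group, gives a 1.6-fold lower number from compound 3 to compound 4 (0.21 log units; within the scatter) and the change from 2,5-dimethoxyphenyl to 2-(methylsulfanyl)phenyl gives a 1.2-fold lower number from compound 1 to compound 4 (0.08 log units; within the scatter), so neither step leaves the scatter. Going by these compounds alone, the change from 2,4-difluorophenyl to 2-(methylsulfanyl)phenyl gives a 2.4-fold lower number from compound 2 to compound 4 (0.37 log units; beyond the scatter), the first step at this position to pass beyond the scatter, though only modestly. Nothing available explains these steps. Still open, on these data alone, is how a phenyl carrying an amine or a carboxylic acid at this place would compare. Also open, as far as these compounds go, is whether any other group here can separate from 2,4-difluorophenyl.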